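Swapping Fluoro for Chloro on the Pendant Aryl Ring

The source may report more compounds than this note shows. Statements on the series, on what has been measured and on what is new or still open speak of the compounds shown alone.

Compound 1 `O=C(Nc1nc2ccc(F)cc2s1)c1cn(-c2ccccc2)nc1-c1ccc(F)cc1` gives 12500 nM in a functional assay on U-87MG ATCC cells for cytotoxicity against U-87 MG (Homo sapiens), read by MTT assay, with a stated time of 72 h; on this read-out higher numbers stand for weaker inhibition and lower numbers for stronger inhibition. Compound 2 `O=C(Nc1nc2ccc(Cl)cc2s1)c1cn(-c2ccccc2)nc1-c1ccc(F)cc1` gives 6770 nM in this assay. For compound 3 `Cc1ccc2nc(NC(=O)c3cn(-c4ccccc4)nc3-c3ccc(F)cc3)sc2c1`, this assay reports only a limit of > 50000 nM, so compound 3 sits beyond the highest number given here, at the limit of > 50000 nM in this assay, at which 1 of the 3 values shown sits. Compound 4 `Cc1ccc2nc(NC(=O)c3cn(-c4ccccc4)nc3-c3ccc(Cl)cc3)sc2c1` differs from compound 3 by chloro in place of fluoro on an aromatic carbon. Within the data shown here, the one measured step of the same kind, a 1.8-fold lower number from compound 1 to compound 2 (0.27 log units; within the scatter), sat on a different ring and stayed within the scatter, while an at least 4.0-fold higher number from compound 1 to compound 3 (0.60 log units; beyond the scatter) and an at least 7.3-fold higher number from compound 2 to compound 3 (0.86 log units; beyond the scatter) show how far back compound 3 lies. Compound 4 is therefore expected to show no step beyond the scatter, a step that the limit leaves unreadable from compound 3 to compound 4. Compound 4 is estimated at 60000 nM, within 25000 nM to 150000 nM, and most likely again only a limit.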

Compound 4, half-maximal inhibitory concentration: 33200 nM
Beside the measured number, compound 4's estimate is 1.8-fold (0.26 log units) above it; measured number inside the range.
By their numbers in this assay, from the lowest: compounds 2 and 1 (each within the scatter of the next); then compound 4. At a limit, above all of these: compound 3.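

Compound 3 stands only at a limit, > 50000 nM. The 4-fluorophenyl to 4-chlorophenyl change, made para to a large group, gives compound 4 a measured number in this assay and reads as an at least 1.5-fold lower number from compound 3 to compound 4 (0.17 log units; that floor lies within the scatter), so the swap at this place can be read only in one direction and with no upper bound on its size. It can now be set beside the same swap on a different ring: the same change on two cores in this assay, a 1.8-fold lower number (0.27 log units; within the scatter) from compound 1 to compound 2 and an at least 1.5-fold lower number (0.17 log units; that floor lies within the scatter) from compound 3 to compound 4; the limit leaves it open whether they differ

From the compounds shown here alone, the true size of this step remains open. So does the effect of an amine or a carboxylic acid at this place.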